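A few compounds are considered here, and "the series" means these few. Any claim that something is new, unique, unknown or untested is made for them only; others in the source may bear on it.

Working notes on the series. Within the data shown here, compound 2 `CN(C)Cc1cc(=O)oc2cc(OCc3ccccc3)ccc12` holds the lower of the two numbers so far in an assay for inhibition of Amine oxidase [flavin-containing] B (Rattus norvegicus) (a higher number here means a weaker inhibitor, a lower number a stronger inhibitor), where compound 2 gives 1800 nM. Among the measured compounds shown here, compound 1 `NC(=O)[C@@H]1CCCN1c1cc(=O)oc2cc(OCc3ccccc3)ccc12` gives 16100 nM in this assay, and the one measured step, an 8.9-fold lower number from compound 1 to compound 2 (0.95 log units; beyond the scatter), ties the two together. Compound 3 `NCc1cc(=O)oc2cc(OCc3ccccc3)ccc12` has not been measured; it differs from compound 2 by amino in place of dimethylamino on a saturated chain carbon bound to an aromatic carbon. For the measured compounds named here, no measured step bears directly on this change: the single step on record, an 8.9-fold lower number from compound 1 to compound 2 (0.95 log units; beyond the scatter), replaces a whole ring-bearing substituent on the aromatic carbon and is not a comparison of amino with dimethylamino on the same chain. With no guide of that kind, the expectation is that the number stays close to that of compound 2, with the wider uncertainty of an untested change. The expected step is a 1.4-fold higher number from compound 2 to compound 3 (0.14 log units; within the scatter). Compound 3 is estimated at 2500 nM, within a range of 600 nM to 10000 nM.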

Compound 3, half-maximal inhibitory concentration: 21 nM
Beside the measured number, compound 3's estimate is 120-fold (2.08 log units) above it, and the stated range ends above it.
By their numbers in this assay, from the lowest: compound 3; then compound 2; then compound 1.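

In this assay, among these compounds, the substituent on this saturated chain carbon bound to an aromatic carbon turns out to matter far more than the earlier compounds could show: amino in place of dimethylamino gives an 86-fold lower number from compound 2 to compound 3 (1.93 log units; beyond the scatter), although the change only goes from 3 heavy atoms and no hydrogen-bond donor to 1 heavy atom and 1 hydrogen-bond donor. Across the whole substituent, aminomethyl in place of 2-carbamoylpyrrolidin-1-yl gives a 770-fold lower number from compound 1 to compound 3 (2.88 log units; beyond the scatter), and the larger part of that span lies in the amino for dimethylamino change alone. Nothing at hand explains the size of this step.

Open, going by these compounds, is whether methylamino, with a single methyl group on the nitrogen, falls nearer to amino or to dimethylamino. Also open, on these data alone, is whether a longer chain, such as aminoethyl, keeps the number of compound 3.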